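One More Methoxy Group: Expecting Little Change

The source may report more compounds than this note shows. Statements on the series, on what has been measured and on what is new or still open speak of the compounds shown alone.

Measured compounds in a functional assay on UO-31 cells (Homo sapiens) for inhibition, read by sulforhodamine B assay, with a stated time of 48 h; on this read-out lower numbers stand for stronger inhibition of growth and higher numbers for weaker inhibition of growth:
- compound 1, `COc1ccc(-c2cc(/C=C/C(=O)c3cc(OC)c(OC)c(OC)c3)[nH]n2)cc1OC`: 2590 nM
- compound 2, `COc1ccc(C(=O)/C=C/c2cc(-c3cc(OC)c(OC)c(OC)c3)n[nH]2)cc1`: 2840 nM
- compound 3, `COc1ccc(C(=O)/C=C/c2cc(-c3cc(OC)c(OC)c(OC)c3)n[nH]2)cc1OC`: 2570 nM

All three measured compounds share the same core and differ only in how many methoxy groups sit on one or the other of the two six-membered aromatic rings of carbon only. Their numbers in this assay lie very close together. Compound 3 gives the lowest number of the three, but its nearest neighbour, compound 1, and its furthest, compound 2, both sit within the usual scatter of it, so no order among them can be claimed.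

Among the measured compounds shown here, the one single-change step available, a 1.1-fold lower number from compound 2 to compound 3 (0.04 log units; within the scatter), adds a methoxy group to an aromatic carbon and leaves the number essentially where it was.

Compound 4, `COc1cc(C(=O)/C=C/c2cc(-c3cc(OC)c(OC)c(OC)c3)n[nH]2)cc(OC)c1OC`, is reached from compound 3 by the same kind of change, (methoxy in place of hydrogen on an aromatic carbon), on the same ring: the ring already bearing two methoxy groups receives a third one, ortho to a methoxy group, meta to a large group and meta to a methoxy group. Since the earlier methoxy addition gave a step within the scatter, the expectation for compound 4 is a step that is also within the scatter, a 1.0-fold lower number from compound 3 to compound 4 (0.01 log units; within the scatter). Compound 4 is therefore estimated to give about 2500 nM in this assay, with a range from 1200 nM to 5500 nM.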

Compound 4, concentration for total growth inhibition: 2480 nM
Compound 4: the middle estimate sits 1.0-fold (0.00 log units) above what was measured; the measured number falls inside the stated range.
By their numbers in this assay, from the lowest: compounds 4, 3, 1 and 2 (each within the scatter of the next).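

In this assay, a third methoxy group on the ring that already carries two gives a 1.0-fold lower number from compound 3 to compound 4 (0.02 log units; within the scatter), so a methoxy group at this place, ortho to a methoxy group and meta to a large group, produces no step beyond the scatter, just as the first addition to this ring did not. The same exchange on the other aromatic ring gives a 1.0-fold lower number from compound 1 to compound 4 (0.02 log units; within the scatter), which shows that the lack of a readable step is not confined to one ring among these compounds. Two of these steps can be compared directly, and their sizes agree within the scatter: the same change on two cores in this assay, a 1.1-fold lower number (0.04 log units; within the scatter) from compound 2 to compound 3 and a 1.0-fold lower number (0.02 log units; within the scatter) from compound 1 to compound 4, 1.1-fold (0.02 log units) apart, within the scatter of two such steps.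

Going by these compounds, all of these steps exchange hydrogen for methoxy, so it remains open whether a different group at this position, such as an amine, a carboxylic acid or a longer chain, would also leave the read-out within the scatter. The numbers also cannot say why these additions produce no readable step, or whether the same would hold for these compounds in any other test.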